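The source may hold more compounds than are shown below. What is called first, only, known or untested is meant among the compounds shown, and "the series" means these compounds.

Series notes. Three analogues of the shared core carry the same ethyl ester chain on the amine nitrogen and differ only in the group attached to that nitrogen. Compound 1 `CCOC(=O)CN(c1ccccc1)[C@H]1c2cc(C#N)ccc2OC(C)(C)[C@@H]1O` bears a phenyl group; in a functional assay (aorta) with Rattus norvegicus as the target (on this read-out higher numbers stand for weaker inhibition and lower numbers for stronger inhibition), compound 1 returns only the limit of > 30000 nM. Compound 2 `CCOC(=O)CN(c1ccc(F)cc1)[C@H]1c2cc(C#N)ccc2OC(C)(C)[C@@H]1O` bears a 4-fluorophenyl group; in this assay compound 2 likewise returns the limit of > 30000 nM. Among the compounds with values here, compound 3 `CCOC(=O)CN(c1nc(C)cs1)[C@H]1c2cc(C#N)ccc2OC(C)(C)[C@@H]1O` bears a 4-methyl-1,3-thiazol-2-yl group; in this assay compound 3 gives 84000 nM, the only numerical value in the set, so compound 3 is the one fixed point here. The three steps among these compounds, a step that the two limits leave unreadable from compound 1 to compound 2, a step that the limit leaves unreadable from compound 1 to compound 3 and a step that the limit leaves unreadable from compound 2 to compound 3, cannot be sized: the limit of > 30000 nM in this assay, at which 2 of the 3 values shown sit, covers two of the three values. Compound 4 `CCOC(=O)CN(c1nc2ccccc2o1)[C@H]1c2cc(C#N)ccc2OC(C)(C)[C@@H]1O` is not yet measured; it differs from compound 3 by 1,3-benzoxazol-2-yl in place of 4-methyl-1,3-thiazol-2-yl on an amine nitrogen. No readable step bears on this change, and the set holds no measured effect of exchanging the group on the amine nitrogen. The expectation is therefore a step no larger than the scatter, a 1.2-fold lower number from compound 3 to compound 4 (0.08 log units; within the scatter), with a wide range around it. For compound 4 in this assay the estimate is 70000 nM, between 15000 nM and 300000 nM, with a real chance that only a limit is returned.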

Compound 4, half-maximal inhibitory concentration: > 30000 nM
Compound 4: no number, only a limit (the forecaster's own chance of this, stated with the estimate: 55%); the middle value is on the limit's open side.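

In this assay compound 4 gives > 30000 nM as a limit only. No new step can be read between compound 4 and compound 1, compound 2 or compound 3, because the comparisons run into this limit: the limit of > 30000 nM in this assay, at which 3 of the 4 values shown sit. The compounds shown leave open whether exchanging the group on the amine nitrogen changes inhibition in this assay at all.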